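Removing the nitro group: from compound 2 to compound 4

The compounds below may be only part of what the source reports. "The series", "measured", "known", "first", "only" and "open" are said of these compounds alone.

Measured so far:
- compound 1 `Cc1ccc(Nc2cncc(N3CC4CC(C3)N4)c2)cc1`: 1.4 nM
- compound 2 `O=[N+]([O-])c1ccc(Nc2cncc(N3CC4CC(C3)N4)c2)cc1`: 0.684 nM
- compound 3 `FC(F)(F)c1ccc(Nc2ccc(N3CC4CC(C3)N4)cn2)cc1`: 0.818 nM

In an assay on HEK293 cells for displacement of a labelled ligand from Neuronal acetylcholine receptor; alpha3/beta4 (Homo sapiens) (a lower number here means a stronger inhibitor, a higher number a weaker inhibitor), compound 2 shows the lowest of the three numbers, but its gap to compound 3 lies within the scatter, so the two cannot be ranked; only compound 1 sits clearly higher, with a gap beyond the scatter. Compound 4 `c1ccc(Nc2cncc(N3CC4CC(C3)N4)c2)cc1` is not yet measured. It differs from compound 2 by hydrogen in place of nitro on an aromatic carbon, the nitro leaving and a hydrogen entering on an aromatic carbon para to a large group. For the measured compounds named here, one measured step bears on this change: a 2.0-fold lower number from compound 1 to compound 2 (0.31 log units; beyond the scatter), in which a nitro in place of a methyl gave a modest lowering. Taking the nitro away again, to hydrogen rather than methyl, is therefore expected to move the number modestly upward, roughly back toward compound 1. The account expects compound 4 to give about 1.3 nM in this assay, within a range of 0.5 nM to 3.5 nM. This amounts to an expected step of a 1.9-fold higher number from compound 2 to compound 4 (0.28 log units; within the scatter), which may or may not clear the scatter.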

Compound 4, inhibition constant: 0.799 nM
Compound 4: the middle estimate sits 1.6-fold (0.21 log units) above what was measured, and the stated range covers the measured number.
By their numbers in this assay, from the lowest: compounds 2, 4, 3 and 1 (each within the scatter of the next, the first and the last beyond it).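

In this assay, replacing the nitro group with hydrogen on this aromatic carbon gives a step within the scatter (a 1.2-fold higher number from compound 2 to compound 4 (0.07 log units; within the scatter)), so the number of compound 2 does not depend on having a nitro group at this position. Hydrogen in place of methyl also stays within the scatter (a 1.8-fold lower number from compound 1 to compound 4 (0.24 log units; within the scatter)), which leaves compound 4 indistinguishable from both compound 1 and compound 2, and the step between those two (a 2.0-fold lower number from compound 1 to compound 2 (0.31 log units; beyond the scatter)) is the only one of the three that clears the scatter, and only modestly. No measurement given here accounts for these numbers.

It remains open whether this position accepts other groups as readily, since only hydrogen, methyl and nitro are shown on it. An amine, a carboxylic acid or a longer chain on the same carbon could give a much larger step.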